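A Change at the Amide Side Chain and Expected Cytotoxicity

The compounds below may be only part of what the source reports. "The series", "measured", "known", "first", "only" and "open" are said of these compounds alone.

Compound 1, `CN1CCN(CC(=O)Nc2ccc(-c3nc4cc(C(F)(F)F)ccc4n3C)cc2)CC1`: > 100000 nM
Compound 2, `COc1ccc(-c2nc3cc(C(F)(F)F)ccc3[nH]2)c(OC)c1`: > 100000 nM
Compound 3, `COc1ccc(-c2nc3cc([N+](=O)[O-])ccc3[nH]2)c(OC)c1OC`: > 100000 nM

All three measured compounds were tested in an ADME assay on Vero cells (Chlorocebus sabaeus) for cytotoxicity; on this read-out higher numbers stand for lower toxicity in this test and lower numbers for higher toxicity in this test. Compound 1 gives > 100000 nM, which is a limit of this assay and not a number. Compound 2 likewise reaches only the limit > 100000 nM. Compound 3 also stops at the limit > 100000 nM. Compound 1 therefore stands at the limit of > 100000 nM in this assay, at which 3 of the 3 values shown sit, where every value shown sits, and nothing in these numbers separates it from the other two.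

Compound 4, `CCN(CC)CC(=O)Nc1ccc(-c2nc3cc(C(F)(F)F)ccc3n2C)cc1`, has not yet been measured in this assay. It differs from compound 1 in one place: diethylamino in place of 4-methylpiperazin-1-yl on a saturated chain carbon bound to a carbonyl carbon. Going by the values given here, no measured pair of compounds differs in a single place, so no step of known size is available to guide the expectation, and the change has to be judged from the limits alone.

Because compound 1 sits at the limit of > 100000 nM in this assay, at which 3 of the 3 values shown sit, the step expected in this assay is a number no higher from compound 1 to compound 4 (the limit leaves the size open), that is, none beyond the usual scatter. Compound 4 is thus expected to give about 100000 nM, within a range from 50000 nM to 300000 nM. It is expected that compound 4 will most likely again be reported only as a limit.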

Compound 4, half-maximal cytotoxic concentration: 90000 nM
Beside the measured number, compound 4's estimate is 1.1-fold (0.05 log units) above it; the measured number falls inside the stated range.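

Replacing 4-methylpiperazin-1-yl with diethylamino on a saturated chain carbon bound to a carbonyl carbon gives the first actual number rather than a limit in this assay, so this position now has a measured value and is no longer known only from a limit. The change, which removes the ring and leaves an open-chain amine, is read as an at least 1.1-fold lower number from compound 1 to compound 4 (0.04 log units; that floor lies within the scatter); a ring at this place is therefore not required for a value of this order in this assay. The step can be given only as a floor, and its true size remains open, as the starting point shows: the limit of > 100000 nM in this assay, at which 3 of the 4 values shown sit.

With only compound 1 and compound 4 differing at this place, the compounds shown cannot tell whether the number in this assay depends on the ring, on the second ring nitrogen or on the size of the amine. As far as these compounds go, a morpholine ring, a dimethylamino group or a longer chain carrying the diethylamino group would each test a different one of these, and what they would give remains open.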